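The compounds below may be only part of what the source reports. "The series", "measured", "known", "first", "only" and "open" are said of these compounds alone.

Measured in a functional assay on DU-145 cells (Homo sapiens) for inhibition, read by trypan blue exclusion, with a stated time of 96 h; on this read-out higher numbers stand for weaker inhibition of growth and lower numbers for stronger inhibition of growth:
- compound 1 `O=C(/C(=C\c1c(O)cc(O)cc1O)S(=O)(=O)c1ccccc1Br)c1ccc(Cl)cc1`: 50000 nM
- compound 2 `O=C(/C(=C\c1c(O)cc(O)cc1O)SCc1ccc(Cl)cc1)c1ccc(Cl)cc1`: > 100000 nM
- compound 3 `O=C(/C(=C\c1c(O)cc(O)cc1O)S(=O)(=O)c1ccc(Br)cc1)c1ccc(Cl)cc1`: > 100000 nM

Compound 2 gives > 100000 nM, which is a limit of the assay and not a number. Compound 3 gives > 100000 nM, also a limit. Compound 2 therefore stands at the limit of > 100000 nM in this assay, at which 2 of the 3 values shown sit.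

The step to compound 4 `CSc1ccc(/C=C(/SCc2ccc(Cl)cc2)C(=O)c2ccc(Cl)cc2)cc1` exchanges one group: 4-(methylsulfanyl)phenyl in place of 2,4,6-trihydroxyphenyl on a double-bonded chain carbon bound to a double-bonded chain carbon, (4-(methylsulfanyl)phenyl in place of 2,4,6-trihydroxyphenyl on a double-bonded chain carbon bound to a double-bonded chain carbon).

Going by the values given here, no measured step changes this group, so the support is only indirect. Changes at a different group gave an at least 2.0-fold higher number from compound 1 to compound 2 (0.30 log units; that floor lies within the scatter), then an at least 2.0-fold higher number from compound 1 to compound 3 (0.30 log units; that floor lies within the scatter), and finally a step that the two limits leave unreadable from compound 2 to compound 3. None of these gives a readable size to carry over, so only a step within the scatter or a small one towards a lower number is expected in this assay, and another limit is quite possible.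

The expected change is an at least 1.2-fold lower number from compound 2 to compound 4 (0.09 log units; that floor lies within the scatter).

The estimate for compound 4 is 80000 nM, with an expected range of 20000 nM to 200000 nM.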

Compound 4, concentration for 50% growth inhibition: 25000 nM
The estimate for compound 4 lay 3.2-fold (0.51 log units) above the measured number, and the stated range covers the measured number.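

Going by these compounds alone, putting 4-(methylsulfanyl)phenyl in place of 2,4,6-trihydroxyphenyl on this double-bonded chain carbon gives an at least 4.0-fold lower number from compound 2 to compound 4 (0.60 log units; beyond the scatter) in this assay, the first readable step at this place. The true size of the step may be larger, since compound 2 sits at a limit of the assay and not at a number: the limit of > 100000 nM in this assay, at which 2 of the 4 values shown sit. The result also shows that, with the (4-chlorobenzyl)sulfanyl group in place, growth inhibition can be measured without the 2,4,6-trihydroxyphenyl group, even though the entering group has 0 hydrogen-bond donors against 3 in the group that leaves.

As far as these compounds go, whether the step comes from losing the hydroxyl groups or from gaining the methylsulfanyl group stays open, since both changes happen at once. Also open, from the compounds shown here alone, is how a phenyl ring carrying an amine or a carboxylic acid would read at this place.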